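The source may report more compounds than this note shows. Statements on the series, on what has been measured and on what is new or still open speak of the compounds shown alone.

Working notes on the series. In an ADME assay on HeLa cells (Homo sapiens) for cytotoxicity, read by resazurin assay, with a stated time of 2 days (on this read-out lower numbers stand for stronger inhibition and higher numbers for weaker inhibition), compound 1 `Cn1c([N+](=O)[O-])cnc1/C=C/c1ccccc1` gives > 100000 nM, and this value is a limit of the assay. Compound 2 `Cc1cccc(/C=C/c2ncc([N+](=O)[O-])n2C)c1` gives 30900 nM. Compound 3 `Cn1c([N+](=O)[O-])cnc1/C=C/c1cccc(Br)c1` gives 87100 nM, the higher of the two actual numbers. Compound 4 `Cn1c([N+](=O)[O-])cnc1/C=C/c1cccc(Cl)c1` differs from it by chloro in place of bromo on an aromatic carbon, with chloro in place of bromo on an aromatic carbon, meta to a large group. For the measured compounds named here, the closest precedent is an at least 1.1-fold lower number from compound 1 to compound 3 (0.05 log units; that floor lies within the scatter), whose floor lies within the scatter. The clear changes, an at least 3.2-fold lower number from compound 1 to compound 2 (0.51 log units; beyond the scatter) and a 2.8-fold higher number from compound 2 to compound 3 (0.45 log units; beyond the scatter), both involve methyl, so they bear on this swap less directly. In this assay, no change beyond the scatter is expected. The expected step is a 1.2-fold lower number from compound 3 to compound 4 (0.09 log units; within the scatter). For compound 4 the estimate is 70000 nM, with an expected range of 35000 nM to 100000 nM.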

Compound 4, half-maximal inhibitory concentration: 30200 nM
Beside the measured number, compound 4's estimate is 2.3-fold (0.37 log units) above it; measured number below the stated range.
By their numbers in this assay, from the lowest: compounds 4 and 2 (each within the scatter of the next); then compound 3. At a limit, above all of these: compound 1.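

In this assay the choice of halogen counts at this position, with a 2.9-fold lower number from compound 3 to compound 4 (0.46 log units; beyond the scatter) showing that chloro and bromo are not interchangeable here, which the bromo step from hydrogen could not show. Chloro and methyl are not told apart, with a 1.0-fold lower number from compound 2 to compound 4 (0.01 log units; within the scatter) as their step. Chloro in place of hydrogen gives an at least 3.3-fold lower number from compound 1 to compound 4 (0.51 log units; beyond the scatter) as a floor only: the limit of > 100000 nM in this assay, at which 1 of the 4 values shown sits.

As far as these compounds go, whether an amine or a methoxy group at this position would sit with chloro and methyl or with bromo stays open. From the compounds shown here alone, whether the gap between chloro and bromo holds elsewhere on the six-membered ring also stays open.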